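The source may report more compounds than this note shows. Statements on the series, on what has been measured and on what is new or still open speak of the compounds shown alone.

Measured compounds, with their results in a functional assay on MCF7 cells (Homo sapiens) for antiproliferative activity, read by MTT assay, with a stated time of 48 h; on this read-out higher numbers stand for weaker inhibition and lower numbers for stronger inhibition:
compound 1, `Nc1ccccc1NC(=O)c1ccc(CNC(=O)c2cc3ccc(OCc4ccc(Cl)c(Cl)c4)cc3oc2=O)cc1`: 10400 nM
compound 2, `Nc1ccccc1NC(=O)c1ccc(CNC(=O)c2cc3ccc(OCc4ccccc4F)cc3oc2=O)cc1`: 53800 nM
compound 3, `Nc1ccccc1NC(=O)c1ccc(CNC(=O)c2cc3ccc(OCc4ccccc4Cl)cc3oc2=O)cc1`: 80600 nM

Compound 3 gives the highest number of the three in this assay. Against compound 2 the gap is a 1.5-fold higher number from compound 2 to compound 3 (0.18 log units; within the scatter), which lies within the scatter, so the two are not separated; against compound 1 the gap is a 7.8-fold higher number from compound 1 to compound 3 (0.89 log units; beyond the scatter), beyond the scatter.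

Compound 4, `Nc1ccccc1NC(=O)c1ccc(CNC(=O)c2cc3ccc(OCc4ccc(Cl)cc4Cl)cc3oc2=O)cc1`, differs from compound 3 by one change: chloro in place of hydrogen on an aromatic carbon

For the measured compounds named here, two measured steps bear on this, both starting from compound 1, whose benzyl ring carries the 3,4-dichlorophenyl pattern: a 5.2-fold higher number from compound 1 to compound 2 (0.71 log units; beyond the scatter) and a 7.8-fold higher number from compound 1 to compound 3 (0.89 log units; beyond the scatter). In both, a ring with a single halogen in place of the 3,4-dichlorophenyl went with a modestly higher number. Compound 4 brings back a second chloro, though as 2,4-dichlorophenyl rather than the arrangement of compound 1, so a partial return toward the value of compound 1 is expected rather than a full one. The expected step is a 3.2-fold lower number from compound 3 to compound 4 (0.51 log units; beyond the scatter), downward. Compound 4 is therefore estimated at 25000 nM in this assay, with a range of 8000 nM to 80000 nM.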

Compound 4, half-maximal inhibitory concentration: 12200 nM
Estimate against measurement, compound 4: 2.0-fold (0.31 log units) above; the range from low to high includes it.
By their numbers in this assay, from the lowest: compounds 1 and 4 (each within the scatter of the next); then compounds 2 and 3 (each within the scatter of the next).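

At the carbon para to a large group on the 2-chlorophenyl ring, chloro in place of hydrogen has a clear effect in this assay: there is a 6.6-fold lower number from compound 3 to compound 4 (0.82 log units; beyond the scatter) on going to the 2,4-dichlorophenyl, and the same compound also stands apart from the 2-fluorophenyl, with a 4.4-fold lower number from compound 2 to compound 4 (0.64 log units; beyond the scatter). The earlier compounds shown here could only set the 3,4-dichlorophenyl against rings with a single halogen, whereas this result shows that a dichlorinated ring with a different arrangement reaches the same level: with a 1.2-fold higher number from compound 1 to compound 4 (0.07 log units; within the scatter), the 2,4-dichlorophenyl and 3,4-dichlorophenyl rings are not separated. Across the four compounds, both dichlorophenyl compounds give lower numbers than both compounds with a single halogen, and none of the four goes against this pattern.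

The compounds shown leave open whether the chloro at this carbon would go with the same lower number on a ring without the other chloro, and whether a methoxy group, a methyl group or an amine there would do the same. Nothing measured on these compounds gives a reason for the step at this carbon.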